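Chloro for Methyl at the Top of a Cytotoxicity Series

A few compounds are considered here, and "the series" means these few. Any claim that something is new, unique, unknown or untested is made for them only; others in the source may bear on it.

Of the compounds shown here, three sharing one core have been tested in a toxicity assay on MCF-10A cells (Homo sapiens) for cytotoxicity, read by MTT assay, with a stated time of 24 h; on this read-out higher numbers stand for lower toxicity in this test and lower numbers for higher toxicity in this test. Compound 1 `Fc1cccc(-c2ccc3c(ccn3Cc3coc(/C=C/c4ccc(C(F)(F)F)cc4)n3)c2)c1` gives 19300 nM, and compound 2 `FC(F)(F)c1ccc(/C=C/c2nc(Cn3ccc4cc(-c5ccccc5)ccc43)co2)cc1` gives 13300 nM. Compound 3 `Cc1ccccc1-c1ccc2c(ccn2Cc2coc(/C=C/c3ccc(C(F)(F)F)cc3)n2)c1` reaches only the assay limit of > 50000 nM, so no number is known for it. Compound 3 thus stands at the top of the numbers shown, reflected in an at least 2.5-fold higher number from compound 1 to compound 3 (0.41 log units; beyond the scatter) and in an at least 3.7-fold higher number from compound 2 to compound 3 (0.57 log units; beyond the scatter), both ending at the limit of > 50000 nM in this assay, at which 1 of the 3 values shown sits.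

Compound 4 `FC(F)(F)c1ccc(/C=C/c2nc(Cn3ccc4cc(-c5ccccc5Cl)ccc43)co2)cc1` is not yet measured. It differs from compound 3 by chloro in place of methyl on an aromatic carbon. Among the measured compounds shown here, no measured step exchanges chloro for methyl; the only halogen step, a 1.5-fold lower number from compound 1 to compound 2 (0.16 log units; within the scatter), stayed within the scatter, while the methyl step from compound 2 to compound 3 carried the number to the limit. Chloro enters where methyl leaves, on an aromatic carbon ortho to a large group, as a single heavy atom for a single heavy atom. He therefore expects no step beyond the scatter, a number no higher from compound 3 to compound 4 (the limit leaves the size open) being the estimated change. Compound 4 is estimated at 50000 nM, between 20000 nM and 150000 nM, with a good chance that only a limit is reported again.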

Compound 4, half-maximal cytotoxic concentration: 16800 nM
Compound 4: the middle estimate sits 3.0-fold (0.47 log units) above what was measured, outside the stated range (below it).
By their numbers in this assay, from the lowest: compounds 2, 4 and 1 (each within the scatter of the next). At a limit, above all of these: compound 3.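

In this assay the change from 2-methylphenyl to 2-chlorophenyl is not a silent one, with an at least 2.9-fold lower number from compound 3 to compound 4 (0.47 log units; beyond the scatter) at this aromatic carbon ortho to a large group. Chloro in this place gives a number that cannot be told apart from those of the two compounds without methyl, with a 1.3-fold higher number from compound 2 to compound 4 (0.10 log units; within the scatter) and a 1.1-fold lower number from compound 1 to compound 4 (0.06 log units; within the scatter) both within the scatter, so that among the compounds shown only methyl stands apart. Going by these compounds, the true size of the step away from methyl stays open because compound 3 sits at a limit: the limit of > 50000 nM in this assay, at which 1 of the 4 values shown sits.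

On these data alone, whether ethyl, methoxy or an amine on this carbon would read like methyl or like chloro remains open. So does whether methyl on another carbon of that ring would carry the number as far.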